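This account rests on a few compounds, and the source may have more. Where it says the series, first, only, none or still open, it means among the compounds named here.

Measured in an ADME assay on microsomes from liver (Mus musculus) for metabolic stability, read by LC-MS, using NADPH, with stated times of 10 min and 30 min, tested at 1 uM; a higher number here means faster removal of the compound, a lower number slower removal:
- compound 1 `COC(=O)C1=C(CN2CCNCC2)NC(c2nccs2)=NC1(C)c1ccc(F)cc1`: 39 mL/min/kg
- compound 2 `COC(=O)C1=C(CN2CC3CC2CO3)NC(c2nccs2)=NC1(C)c1ccc(F)cc1`: 84 mL/min/kg

Of these two compounds, compound 2 holds the higher number, at 84 mL/min/kg. The next compound, compound 3 `COC(=O)C1=C(CN2CCOCC2=O)NC(c2nccs2)=NC1(C)c1ccc(F)cc1`, has not been measured. Its change from compound 2 is a group of 7 heavy atoms (4 carbon, 1 nitrogen, 2 oxygen; one six-membered non-aromatic ring with 2 hetero atoms) in place of a group of 7 heavy atoms (5 carbon, 1 nitrogen, 1 oxygen; 2 five-membered non-aromatic rings with 1 hetero atom each), on a saturated chain carbon bound to a double-bonded ring carbon; the entering group is 3-oxomorpholin-4-yl. Among the compounds with values here, one measured step bears on this change, at the same place: a 2.2-fold higher number from compound 1 to compound 2 (0.33 log units; beyond the scatter), a modest step. Compound 3 shares one six-membered non-aromatic ring with 2 hetero atoms at this place with compound 1, which gives 39 mL/min/kg, so a lower number in this assay is expected. With a single step as guide, the expected change is small: a 1.5-fold lower number from compound 2 to compound 3 (0.18 log units; within the scatter). For compound 3 the estimated value is 55 mL/min/kg, with an expected range of 28 mL/min/kg to 100 mL/min/kg.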

Compound 3, clearance in the Mus musculus assay: 80 mL/min/kg
Estimate against measurement, compound 3: 1.5-fold (0.16 log units) below; the measured number falls inside the stated range.
By their numbers in the Mus musculus assay, from the lowest: compound 1; then compounds 3 and 2 (each within the scatter of the next).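

In the Mus musculus assay, a six-membered non-aromatic ring with 2 hetero atoms on this saturated chain carbon does not by itself go with the lower number, which compound 1 gives at 39 mL/min/kg: 3-oxomorpholin-4-yl in place of piperazin-1-yl gives a 2.1-fold higher number from compound 1 to compound 3 (0.31 log units; beyond the scatter), while replacing the two-ring group of compound 2 gives a 1.1-fold lower number from compound 2 to compound 3 (0.02 log units; within the scatter), so piperazin-1-yl alone stands apart among the three groups. The same exchange of the two-ring group gives in a physicochemical assay for solubility, read by HPLC, in phosphate buffer, at pH 6.5 (on this read-out lower numbers stand for lower solubility and higher numbers for higher solubility), a 1.3-fold lower number from compound 2 to compound 3 (0.11 log units; within the scatter), with compound 2 at 564 ug/mL and compound 3 at 440 ug/mL, so neither read-out separates these two groups. No measurement shown here explains why piperazin-1-yl differs from the other two groups.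

Which feature of piperazin-1-yl goes with its lower clearance remains open, as the three groups differ in more than one feature. A piperidine ring or a dimethylamino group at this place could show whether the number stays near that of compound 1 or near those of compounds 2 and 3.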